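The source may report more compounds than this note shows. Statements on the series, on what has been measured and on what is new or still open speak of the compounds shown alone.

Compound 2 `CC[C@@H](Nc1c(C#N)c(-c2ccc(-c3ccccc3CO)cc2)nc2cnccc12)C(N)=O` sits lowest of the three measured compounds in a physicochemical assay for lipophilicity, read by HPLC, at pH 7.5; a higher number here means a more lipophilic compound, a lower number a more polar compound: compound 2 gives 2.1, while compound 3 `CCOc1ccccc1-c1ccc(-c2nc3cnccc3c(N[C@@H]3CCOC3=O)c2C#N)cc1` gives 2.7 and compound 1 `CCCCC(Nc1c(C#N)c(-c2ccc(-c3ccccc3OCC)cc2)nc2cnccc12)C(N)=O` gives 3.6. Within the data shown here, the one single-point step measured, a number 0.90 log units lower from compound 1 to compound 3 (beyond the scatter), concerns the group on a nitrogen on an aromatic ring, not the ring where the present change sits, so it does not bear on it. Compound 4 `CC[C@@H](Nc1c(C#N)c(-c2ccc(Br)cc2)nc2cnccc12)C(N)=O` differs from compound 2 by bromo in place of 2-(hydroxymethyl)phenyl on an aromatic carbon. Compounds 1 and 3 differ from compound 2 in two places and show only that both sit higher. Only a small step is expected here, a number 0.20 log units higher from compound 2 to compound 4 (within the scatter), with no direction secured beyond the scatter. Compound 4 is thus expected near 2.3, within 1.7 to 2.9.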

Compound 4, distribution coefficient: 2.2
Compound 4: the middle estimate sits 0.10 log units above what was measured; the measured number falls inside the stated range.
By their numbers in this assay, from the lowest: compounds 2 and 4 (each within the scatter of the next); then compound 3; then compound 1.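

In this assay, bromo in place of 2-(hydroxymethyl)phenyl, on an aromatic carbon para to a large group, gives only a small step (a number 0.10 log units higher from compound 2 to compound 4 (within the scatter)). At this position, a single bromine and a group of 8 heavy atoms with a six-membered aromatic ring therefore cannot be told apart in this read-out. No evidence at hand accounts for this match.

Still open, from the compounds shown here alone, is how an unsubstituted phenyl, an amine or a carboxylic acid would read at this position. Also open, going by these compounds, is whether the same small step holds with the 1-carbamoylpentyl group in place.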